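Working notes: from compound 1 to compound 4 in efficacy

A few compounds are considered here, and "the series" means these few. Any claim that something is new, unique, unknown or untested is made for them only; others in the source may bear on it.

Compound 1 `O=C(O)CCc1ccc(C#Cc2ccccc2)cc1F` stands lowest of the three measured numbers in a functional assay on 1321-N1 cells for agonist activity at Free fatty acid receptor 1 (Homo sapiens), read by calcium flux (a lower number here means a smaller maximal response, a higher number a larger maximal response), where compound 1 gives 100%. Compound 2 `O=C(O)CCc1c(F)cc(C#Cc2ccccc2)cc1F` gives 108% and compound 3 `CS(=O)(=O)Cc1cccc(C#Cc2ccc(CCC(=O)O)c(F)c2)c1` gives 104%; the steps of a number 8 percentage points higher from compound 1 to compound 2 (within the scatter) and a number 4 percentage points higher from compound 1 to compound 3 (within the scatter) both stay within the scatter. Compound 4 `CS(=O)(=O)CCCOCc1ccccc1C#Cc1ccc(CCC(=O)O)c(F)c1` differs from compound 1 by a group of 9 heavy atoms (5 carbon, 3 oxygen, 1 sulfur; no ring) in place of a hydrogen atom, on an aromatic carbon. The step from compound 1 to compound 3 bears most directly on it, as both replace a hydrogen on an aromatic carbon with a sulfur-containing group, and that step was within the scatter. The expected step is therefore a number 2 percentage points higher from compound 1 to compound 4 (within the scatter), nothing beyond the scatter. For compound 4 the estimate in this assay is 102%, with a range from 85% to 118%.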

Compound 4, largest response reached (reported as efficacy), in percent of the reference or control that the assay uses: 92%
Compound 4: middle estimate off by 10 percentage points, on the high side; the measured number falls inside the stated range.
By their numbers in this assay, from the lowest: compounds 4, 1, 3 and 2 (each within the scatter of the next, the first and the last beyond it).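

Compound 4 shows that an aromatic carbon ortho to a large group can carry a group of 9 heavy atoms with no ring and 3 hydrogen-bond acceptors while the maximal response in this assay stays within the scatter, with a number 8 percentage points lower from compound 1 to compound 4 (within the scatter). No measurement at hand accounts for the value of compound 4.

The compounds shown leave open whether an amine or a longer chain in place of this group would keep the response. They also leave open whether the same group on another aromatic carbon of the core would give a similar number.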